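The compounds below may be only part of what the source reports. "The series", "measured", "known", "first", "only" and "open" are said of these compounds alone.

Working notes on the series.

Compound 1 `Nc1cccc(Nc2nccc(-c3ccccn3)n2)c1`, compound 2 `Cc1ccsc1-c1ccnc(Nc2ccc(N(C)C)cc2)n1` and compound 3 `Cc1cc(C)cc(Nc2nccc(-c3cccnc3)n2)c1` share a core and have been tested in a functional assay for inhibition, with Homo sapiens as the target; a lower number here means a stronger inhibitor, a higher number a weaker inhibitor. Compound 1 gives 300 nM, compound 3 gives 800 nM, and compound 2 gives 1800 nM. Compound 2 thus stands at the highest number of the three; its nearest neighbour is compound 3, and compound 1 sits furthest below it, both gaps lying beyond the scatter. Within the data shown here, no pair among the measured compounds differs in a single place, so no step can be read directly from them; compound 1 and compound 2 differ in two places at once, and their values can only be set side by side.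

The next compound, compound 4 `CN(C)c1ccc(Nc2nccc(-c3ccccn3)n2)cc1`, is not yet measured. It differs from compound 2 in one place: pyridin-2-yl in place of 3-methylthiophen-2-yl on an aromatic carbon. The same pyridin-2-yl group is carried by compound 1, whose value of 300 nM is the lowest in the set, while the dimethylamino-bearing part of compound 2 is kept. A step of moderate size toward a lower number is expected for compound 4, beyond the scatter, as a 3.6-fold lower number from compound 2 to compound 4 (0.56 log units; beyond the scatter). The estimate for compound 4 in this assay is 500 nM, with a range from 200 nM to 1500 nM.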

Compound 4, half-maximal inhibitory concentration: 3300 nM
For compound 4 the middle estimate is 6.6-fold (0.82 log units) below the measured one; measured number above the stated range.
By their numbers in this assay, from the lowest: compound 1; then compound 3; then compounds 2 and 4 (each within the scatter of the next).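

Pyridin-2-yl in place of 3-methylthiophen-2-yl on this aromatic carbon, next to the ring nitrogen, gives a 1.8-fold higher number from compound 2 to compound 4 (0.26 log units; within the scatter) in this assay, the first direct reading at this position. With the dimethylamino-bearing part kept, the five-membered sulfur-containing ring and the six-membered nitrogen-containing ring are therefore not told apart by this assay. Pyridin-2-yl thus does not by itself mark a compound with a low number in this pair, and no step can be read between compound 4 and compound 1, which differ elsewhere as well. Nothing at hand accounts for this result.

As far as these compounds go, it remains open whether the same exchange stays within the scatter when the aminophenyl part of compound 1 or the dimethylphenyl part of compound 3 takes the place of the dimethylamino-bearing part. From the compounds shown here alone, it also remains open whether a different group on this carbon, such as a plain phenyl ring, a morpholine or a carboxylic acid, would move the number beyond the scatter.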